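Chloro for Methyl on the Carbamoyl Phenyl Ring

The source may hold more compounds than are shown below. What is called first, only, known or untested is meant among the compounds shown, and "the series" means these compounds.

The two measured compounds share one core and differ in two places. Compound 1 `COc1cc2c(Nc3nc4ccc(C(=O)Nc5c(C)cccc5Cl)cc4s3)ncnc2cc1OCCCN1CCCCC1C` carries a 2-chloro-6-methylphenyl on its carbamoyl group; in a functional assay on HCT-116 cells (Homo sapiens) for cytotoxicity, read by WST assay, with a stated time of 72 h (on this read-out higher numbers stand for weaker inhibition and lower numbers for stronger inhibition), compound 1 gives 7200 nM. Compound 2 `COc1cc2c(Nc3nc4ccc(C(=O)Nc5c(C)cccc5C)cc4s3)ncnc2cc1OCCCN1CCC(C)CC1` carries a 2,6-dimethylphenyl there and differs elsewhere as well. In this assay compound 2 gives only a limit, > 100000 nM, and so stands at the limit of > 100000 nM in this assay, at which 1 of the 2 values shown sits, without a number of its own. Compound 3 `COc1cc2c(Nc3nc4ccc(C(=O)Nc5c(C)cccc5Cl)cc4s3)ncnc2cc1OCCCN1CCC(C)CC1` is compound 2 with chloro in place of methyl on an aromatic carbon. Among the compounds with values here, no measured pair isolates this change, so its size cannot be read off directly. Compound 1, which also carries the chloro, gave 7200 nM, so the expected direction is toward stronger inhibition. Compound 3 is expected to reach 20000 nM, between 5000 nM and 100000 nM. The estimated step of an at least 5.0-fold lower number from compound 2 to compound 3 (0.69 log units; beyond the scatter) is expected to exceed the usual scatter, though the limit leaves its true size open.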

Compound 3, half-maximal inhibitory concentration: 9100 nM
Estimate against measurement, compound 3: 2.2-fold (0.34 log units) above; the range from low to high includes it.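

Within the data shown here, with compound 3, the change at this position can be read on its own for the first time: in this assay, chloro in place of methyl on an aromatic carbon gives an at least 10-fold lower number from compound 2 to compound 3 (1.04 log units; beyond the scatter), a large step. Compound 2 has only a limit, not a number: the limit of > 100000 nM in this assay, at which 1 of the 3 values shown sits. With the 2-chloro-6-methylphenyl kept, 4-methylpiperidin-1-yl in place of 2-methylpiperidin-1-yl gives a 1.3-fold higher number from compound 1 to compound 3 (0.10 log units; within the scatter), so these two amines read alike in this setting.

As far as these compounds go, whether this step is special to chloro remains open, as fluoro, bromo and trifluoromethyl at the same place would test that. From the compounds shown here alone, it is also open how the remaining methyl contributes, which a 2-chlorophenyl or 2,6-dichlorophenyl on the carbamoyl group would address.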